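Ethoxy to Fluoro: One Change Carried to a Second Core

This account rests on a few compounds, and the source may have more. Where it says the series, first, only, none or still open, it means among the compounds named here.

Four compounds belong to this small study. Compound 1 `CCOc1ccc2nc(Nc3nc4ccc(F)cc4s3)sc2c1` and compound 2 `Fc1ccc2nc(Nc3nc4ccc(F)cc4s3)sc2c1` share one core, while compound 3 `CCOc1ccc2nc(NC(=S)Nc3ccccc3)sc2c1` and compound 4 `Fc1ccc2nc(NC(=S)Nc3ccccc3)sc2c1` share another; how the two cores differ is not broken down here. All were, or are to be, tested in a functional assay on THP-1 cells (Homo sapiens) for cytotoxicity, read by MTT assay, with a stated time of 48 h; a lower number here means a stronger inhibitor, a higher number a weaker inhibitor. In this assay compound 1 gives 39000 nM, compound 2 gives 17500 nM and compound 3 gives 43800 nM.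

Compound 2 differs from compound 1 in one place: fluoro in place of ethoxy on an aromatic carbon. This change brought a 2.2-fold lower number from compound 1 to compound 2 (0.35 log units; beyond the scatter). Compound 4 differs from compound 3 in exactly the same way: fluoro in place of ethoxy on an aromatic carbon. Among the compounds shown this change appears in these two pairs, and only the first pair has been measured. Compound 3 and compound 1 lie within the usual scatter of each other, while compound 3 and compound 2 lie beyond it.

The expectation for compound 4 rests on a single earlier example. The expected result is that a 2.2-fold lower number from compound 3 to compound 4 (0.34 log units; beyond the scatter), because the same change gave a 2.2-fold lower number from compound 1 to compound 2 (0.35 log units; beyond the scatter). Going by the values given here, since only one example exists and the two cores differ in more than one place, the expectation stays loose. Compound 4 is therefore estimated at 20000 nM in this assay, with a range from 10000 nM to 40000 nM.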

Compound 4, half-maximal inhibitory concentration: 46600 nM
Estimate against measurement, compound 4: 2.3-fold (0.37 log units) below; the measured number lies above the stated range.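

In this assay, putting fluoro in place of ethoxy on the core of compound 3 gives a 1.1-fold higher number from compound 3 to compound 4 (0.03 log units; within the scatter), so this pair cannot be told apart by this measurement, whereas the same change on the core of compound 1 gave a step beyond the scatter. It is tempting to read this as a change that works on one core and fails on the other, but the two steps are no further apart than the noise in two such steps allows: the same change on two cores in this assay, a 2.2-fold lower number (0.35 log units; beyond the scatter) from compound 1 to compound 2 and a 1.1-fold higher number (0.03 log units; within the scatter) from compound 3 to compound 4, 2.4-fold (0.37 log units) apart, within the scatter of two such steps. The result therefore does not show that the core alters the effect of the change, nor does it confirm that the effect carries over, and with one pair on each core, neither possibility can be ruled out.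

As far as these compounds go, only ethoxy and fluoro appear on this aromatic carbon, so it remains open how another group there, such as an amine, a carboxylic acid or a longer chain, would affect the number on either core. From the compounds shown here alone, it also remains open whether the two pairs would compare in the same way in a test other than this cell assay.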